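Hydroxy to Fluoro on the Sulfonyl Aryl Ring

The source may hold more compounds than are shown below. What is called first, only, known or untested is meant among the compounds shown, and "the series" means these compounds.

Going by the values given here, compound 2 `O=S(=O)(Nc1ccc(-c2nc3ccccc3o2)cc1)c1ccc(O)cc1` holds the only number in an assay on cells for inhibition of HSP60/HSP10 (Homo sapiens), with a stated time of 60 min (on this read-out lower numbers stand for stronger inhibition and higher numbers for weaker inhibition), where compound 2 gives 78000 nM. Compound 1 `O=S(=O)(Nc1ccc(-c2nc3ccccc3o2)cc1)c1ccccc1F` gives > 100000 nM in this assay, which is the limit of > 100000 nM in this assay, at which 1 of the 2 values shown sits, a limit rather than a number. Among the compounds with values here, the sole measured step is an at least 1.2-fold lower number from compound 1 to compound 2 (0.10 log units; that floor lies within the scatter). Compound 3 `O=S(=O)(Nc1ccc(-c2nc3ccccc3o2)cc1)c1ccc(F)cc1` differs from compound 2 by fluoro in place of hydroxy on an aromatic carbon. That one step also exchanges a fluorophenyl for a hydroxyphenyl, yet it lies within the scatter, so no step beyond the scatter is expected. The step expected for compound 3 is a 1.3-fold higher number from compound 2 to compound 3 (0.11 log units; within the scatter). Compound 3 is thus estimated at 100000 nM, between 40000 nM and 250000 nM.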

Compound 3, half-maximal inhibitory concentration: 73000 nM
Estimate against measurement, compound 3: 1.4-fold (0.14 log units) above; measured number inside the range.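

In this assay, fluoro in place of hydroxy gives a 1.1-fold lower number from compound 2 to compound 3 (0.03 log units; within the scatter), so at this position the hydrogen-bond donor and acceptor counted on the hydroxy make no difference that can be read beyond the scatter. The 4-fluorophenyl in place of the 2-fluorophenyl gives an at least 1.3-fold lower number from compound 1 to compound 3 (0.13 log units; that floor lies within the scatter), a floor that also lies within the scatter. Compound 1 stands at a limit, not a number: the limit of > 100000 nM in this assay, at which 1 of the 3 values shown sits.

Going by these compounds, what an amine, a carboxylic acid or a longer alkoxy chain would give at this position remains open, as does whether any change here reaches beyond the scatter.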